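One Carbon Shorter: An Estimate for Compound 4

The source may report more compounds than this note shows. Statements on the series, on what has been measured and on what is new or still open speak of the compounds shown alone.

In a functional assay on KMS-11 cells (Homo sapiens) for antiproliferative activity, read by CellTiter-Glo, with a stated time of 72 h (a lower number here means a stronger inhibitor, a higher number a weaker inhibitor), compound 1 `COc1ccc(C(=O)N(Cc2ccncc2)Cc2cccc(OCCc3cccc(C(F)(F)F)c3)c2)cc1` gives 8900 nM, the second highest of the three numbers measured; compound 2 `COc1ccc(C(=O)N(Cc2ccncc2)Cc2cccc(OCCc3ccc(Br)cc3)c2)cc1` gives 8400 nM and compound 3 `COc1ccc(C(=O)N(Cc2ccncc2)Cc2cccc(OCc3ccc([N+](=O)[O-])cc3)c2)cc1` gives 15400 nM. All three sit within the scatter of one another, as the steps of a 1.1-fold lower number from compound 1 to compound 2 (0.03 log units; within the scatter), a 1.7-fold higher number from compound 1 to compound 3 (0.24 log units; within the scatter) and a 1.8-fold higher number from compound 2 to compound 3 (0.26 log units; within the scatter) show. Compound 4 `COc1ccc(C(=O)N(Cc2ccncc2)Cc2cccc(OCc3ccc(C(F)(F)F)cc3)c2)cc1` differs from compound 1 in one place: 4-(trifluoromethyl)phenyl in place of 3-(trifluoromethyl)benzyl on a saturated chain carbon bound to an oxygen on an aromatic ring. The two measured steps that likewise trade a benzyl for a phenyl on the same carbon, a 1.7-fold higher number from compound 1 to compound 3 (0.24 log units; within the scatter) and a 1.8-fold higher number from compound 2 to compound 3 (0.26 log units; within the scatter), stayed within the scatter, so for compound 4 a step of a 1.2-fold higher number from compound 1 to compound 4 (0.09 log units; within the scatter) is expected, leaning higher but not beyond the scatter. Compound 4 is therefore estimated at 11000 nM, with a range from 5000 nM to 25000 nM.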

Compound 4, half-maximal inhibitory concentration: 14300 nM
Beside the measured number, compound 4's estimate is 1.3-fold (0.11 log units) below it; the measured number falls inside the stated range.
By their numbers in this assay, from the lowest: compounds 2, 1, 4 and 3 (each within the scatter of the next).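

Trifluoromethyl in place of nitro on an aromatic carbon, between two compounds that share the shorter chain, stays within the scatter (a 1.1-fold lower number from compound 3 to compound 4 (0.03 log units; within the scatter)). The change to 4-(trifluoromethyl)phenyl on the saturated chain carbon bound to an oxygen on an aromatic ring also stays within it (a 1.6-fold higher number from compound 1 to compound 4 (0.21 log units; within the scatter); a 1.7-fold higher number from compound 2 to compound 4 (0.23 log units; within the scatter)), so a further ring group at this position leaves the reading within the scatter of the others. No evidence at hand bears on these readings.

As far as these compounds go, whether an amine or a carboxylic acid on this ring would move the number beyond the scatter stays open. So does the effect of a longer chain.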